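A few compounds are considered here, and "the series" means these few. Any claim that something is new, unique, unknown or untested is made for them only; others in the source may bear on it.

Measured so far, in a functional assay for inhibition of nuclear factor NF-kappa-B complex (Homo sapiens); on this read-out lower numbers stand for stronger inhibition and higher numbers for weaker inhibition:
compound 1 `COc1ccc2c(c1)OC(c1cc(OC)c(OC)c(OC)c1)C(C(C)=O)=C2` gives 14100 nM.
compound 2 `CCOC(=O)C1=Cc2ccc(OC)cc2OC1c1cc(OC)c(OC)c(OC)c1` gives 25000 nM.
compound 3 `COc1ccc2c(c1)OC(c1cc(OC)c(OC)c(OC)c1)C(C=O)=C2` gives 13500 nM.

Compound 3 sits at the low end of the three numbers, but its steps to the others, a 1.0-fold lower number from compound 1 to compound 3 (0.02 log units; within the scatter) and a 1.9-fold lower number from compound 2 to compound 3 (0.27 log units; within the scatter), both fall within the scatter, so the three compounds are not separable on these data. Compound 4 `CCCCNC(=O)C1=Cc2ccc(OC)cc2OC1c1cc(OC)c(OC)c(OC)c1` differs from compound 3 by butylamino in place of hydrogen on a carbonyl carbon. Among the measured compounds shown here, the steps that bear on this are the other exchanges at the same carbonyl carbon: a 1.8-fold higher number from compound 1 to compound 2 (0.25 log units; within the scatter), a 1.0-fold lower number from compound 1 to compound 3 (0.02 log units; within the scatter) and a 1.9-fold lower number from compound 2 to compound 3 (0.27 log units; within the scatter), none of them beyond the scatter. A further exchange at that place is therefore expected to leave this assay essentially unmoved, the expected step being a 1.1-fold higher number from compound 3 to compound 4 (0.05 log units; within the scatter). Compound 4 is estimated at 15000 nM, with a range of 6000 nM to 40000 nM.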

Compound 4, half-maximal inhibitory concentration: 25500 nM
Beside the measured number, compound 4's estimate is 1.7-fold (0.23 log units) below it; measured number inside the range.
By their numbers in this assay, from the lowest: compounds 3, 1, 2 and 4 (each within the scatter of the next).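

Butylamino, with 5 heavy atoms and 1 hydrogen-bond donor, stays within the scatter of every other group at this carbonyl carbon in this assay: a 1.9-fold higher number from compound 3 to compound 4 (0.28 log units; within the scatter), a 1.0-fold higher number from compound 2 to compound 4 (0.01 log units; within the scatter) and a 1.8-fold higher number from compound 1 to compound 4 (0.26 log units; within the scatter). Across hydrogen, methyl, ethoxy and butylamino, no exchange at this place has yet moved the number beyond the scatter, and adding an amide to the set does not change that.

From the compounds shown here alone, whether a carboxylic acid or a longer chain ending in a tertiary amine would do so remains open. No evidence bears on why these four groups read alike.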